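From Fluoro to Chloro on a Shared Core

The compounds below may be only part of what the source reports. "The series", "measured", "known", "first", "only" and "open" are said of these compounds alone.

Compound 1 `c1ccc(-c2nn(-c3ccccc3)cc2-c2nc3ccccc3[nH]2)cc1`: 2710 nM
Compound 2 `Fc1ccc2[nH]c(-c3cn(-c4ccccc4)nc3-c3ccccc3)nc2c1`: 1720 nM

In a functional assay on A549 cells (Homo sapiens) for antiproliferative activity, read by MTT assay, with a stated time of 48 h (a higher number here means a weaker inhibitor, a lower number a stronger inhibitor), compound 2 gives 1720 nM and compound 1 gives 2710 nM. These two numbers lie within the usual scatter of each other, so the data do not separate the two compounds.

Compound 3 `Clc1ccc2[nH]c(-c3cn(-c4ccccc4)nc3-c3ccccc3)nc2c1` has not yet been measured. It keeps the core of compound 2 and differs in one place: chloro in place of fluoro on an aromatic carbon. In words, this is chloro in place of fluoro on an aromatic carbon.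

Among the compounds with values here, only one measured step bears on this change: a 1.6-fold lower number from compound 1 to compound 2 (0.20 log units; within the scatter), which put fluoro in place of hydrogen on an aromatic carbon. Within the data shown here, that step stays within the scatter, and no measured compound yet carries chloro, so the evidence is thin. Among the measured compounds shown here, with only that small step to go on, no shift beyond the scatter is expected in this assay, and no direction can be favoured with confidence. The expected change is a 1.0-fold lower number from compound 2 to compound 3 (0.01 log units; within the scatter). For compound 3 the estimate is 1700 nM, with an expected range from 750 nM to 3900 nM.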

Compound 3, half-maximal inhibitory concentration: 2370 nM
Compound 3: the middle estimate sits 1.4-fold (0.14 log units) below what was measured; measured number inside the range.
By their numbers in this assay, from the lowest: compounds 2, 3 and 1 (each within the scatter of the next).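

In this assay, the exchange of fluoro for chloro gives a 1.4-fold higher number from compound 2 to compound 3 (0.14 log units; within the scatter) and leaves the result unresolved, while chloro in place of hydrogen gives a 1.1-fold lower number from compound 1 to compound 3 (0.06 log units; within the scatter) and is just as small. This aromatic carbon has now carried hydrogen, fluoro and chloro, and all three compounds lie within the scatter of one another, so a second halogen, and not just fluoro alone, fails to separate from the unsubstituted compound 1 in this cell test. No measurement of any other kind accompanies these numbers, so nothing here can explain why they stay so close.

On these data alone, it remains open whether a group of another kind at this carbon, such as an amine, a methoxy group or a carboxylic acid, would move the number beyond the scatter. As far as these compounds go, it is equally open whether fluoro or chloro would stay as silent on the other aromatic carbons of the same six-membered ring, or whether the placement of a halogen there would begin to matter.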